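A few compounds are considered here, and "the series" means these few. Any claim that something is new, unique, unknown or untested is made for them only; others in the source may bear on it.

Measured compounds:
- Compound 1 `CCCn1c(NC(=O)c2ccc3ccccc3n2)nc2cc(C(N)=O)cc(OC)c21`: in an assay for activation of interferon regulatory factor 3 (Homo sapiens), read by a luciferase reporter, with a stated time of 20 h (a higher number here means that more compound is needed for the effect, a lower number that less compound is needed), compound 1 gives > 100000 nM, which is a limit of the assay, not a number.
- Compound 2 `CCCn1c(NC(=O)c2cncn2C)nc2cc(C(N)=O)cc(OC)c21`: in this assay compound 2 gives > 100000 nM, again a limit.

Within the data shown here, compound 2 therefore stands at the edge of what this assay can report, and it shares that place with the one other measured compound (the limit of > 100000 nM in this assay, at which 2 of the 2 values shown sit). Among the measured compounds shown here, the only measured step, a step that the two limits leave unreadable from compound 1 to compound 2, is left unreadable by the two limits, so its size is unknown.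

Compound 3 `CCCn1c(NC(=O)CCc2ccccc2)nc2cc(C(N)=O)cc(OC)c21` is the next compound; the change is phenethyl in place of 1-methyl-1H-imidazol-5-yl on a carbonyl carbon. No measured step speaks to this change, since the one step shown cannot be read. The expectation for compound 3 in this assay is thus that it stays at the limit as well, with an estimated value of 150000 nM and a range from 30000 nM to 1000000 nM. The expected step that the limit leaves unreadable from compound 2 to compound 3 is accordingly no readable change, with a measured number unlikely.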

Compound 3, half-maximal effective concentration: > 100000 nM
Compound 3: no number, only a limit (the forecaster's own chance of this, stated with the estimate: 80%); the middle value does not contradict the limit.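

Neither step to compound 3, from compound 1 or from compound 2, can be read, since all three compounds share one limit of the assay: the limit of > 100000 nM in this assay, at which 3 of the 3 values shown sit.

The compounds shown leave open whether quinolin-2-yl, 1-methyl-1H-imidazol-5-yl and phenethyl truly differ in this assay, and whether any group on this carbonyl carbon gives a number there.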